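A methyl for a methoxy: what to expect of compound 4

A few compounds are considered here, and "the series" means these few. Any claim that something is new, unique, unknown or untested is made for them only; others in the source may bear on it.

Compound 1 `COc1ccc(C(=O)N2CCN(Cc3nc4ccccc4n3Cc3cccc(C)c3)CC2)cc1` gives 55.5% in an assay on isolated protein for inhibition of aldehyde dehydrogenase 1A1 (Homo sapiens), read by spectrophotometry, tested at 10 uM; a lower number here means less inhibition, a higher number more inhibition at the concentration tested (going by the name of the read-out).
Compound 2 `O=C(C1CC1)N1CCN(Cc2nc3ccccc3n2Cc2ccccc2C(F)(F)F)CC1` gives 56.3%.
Compound 3 `O=C(C1CC1)N1CCN(Cc2nc3ccccc3n2Cc2ccccc2F)CC1` gives 40.7%.

Among these three numbers, compound 1 stands second highest; its value and that of compound 2 lie within the scatter of each other, while compound 3 sits lower by a margin beyond the scatter. Within the data shown here, the only step between measured compounds that differ in one place is a number 15.6 percentage points lower from compound 2 to compound 3 (beyond the scatter), and it concerns a group on a different part of the shared core than the one altered here.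

Compound 4 `Cc1ccc(C(=O)N2CCN(Cc3nc4ccccc4n3Cc3cccc(C)c3)CC2)cc1` differs from compound 1 in one place: methyl in place of methoxy on an aromatic carbon. Among the measured compounds shown here, no measured pair shows this exchange, so the step from compound 2 to compound 3 offers no direct guide, and the comparison of compound 1 with compound 2 only shows that two quite different groups on the other aromatic ring gave values within the scatter. Without a bearing step, the expectation is a change of no more than the scatter, so compound 4 is expected to land near compound 1, giving an estimated 54% in this assay, with a range from 40% to 68%, which means an expected a number 1.5 percentage points lower from compound 1 to compound 4 (within the scatter).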

Compound 4, a percentage reported as inhibition, at one concentration (the size of the read-out at that concentration, not a potency): 64.9%
For compound 4 the middle estimate is 10.9 percentage points below the measured one, within the range that was stated.
By their numbers in this assay, from the lowest: compound 3; then compounds 1, 2 and 4 (each within the scatter of the next).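

In this assay the exchange of methoxy for methyl, on an aromatic carbon para to a large group, gives a number 9.4 percentage points higher from compound 1 to compound 4 (within the scatter). Among these compounds, this is the first reading at this position, and it shows that replacing the 4-methoxyphenyl with the 4-methylphenyl, which removes one hydrogen-bond acceptor and one heavy atom, leaves the inhibition at the tested concentration within the usual scatter, so this single pair shows no clear effect of the exchange in either direction. No available evidence bears on why the two numbers lie so close.

On these data alone, what an amine, a carboxylic acid or a longer chain would give at this same place remains open. Also open, as far as these compounds go, is whether methyl and methoxy would read alike with the other groups on the shared core, since this exchange rests on one pair of compounds at one concentration.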